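The source may hold more compounds than are shown below. What is called first, only, known or untested is meant among the compounds shown, and "the series" means these compounds.

Measured so far:
Compound 1, `COC(=O)N(C)CC#CCN1CCCC1`, gives 3 mg/kg in a functional assay on the whole organism for agonist activity, with Mus musculus as the target; on this read-out lower numbers stand for an effect already at smaller amounts and higher numbers for an effect only at larger amounts of compound.
Compound 2, `COC(=O)N(C)CC#CCn1ccnc1`, gives 4.5 mg/kg in this assay.
Compound 3, `CN(C)C(=O)N(C)CC#CCN1CCCC1`, gives only a limit in this assay, namely > 10 mg/kg.

Compound 2 differs from compound 1 in one place: 1H-imidazol-1-yl in place of pyrrolidin-1-yl on a saturated chain carbon bound to a triple-bonded carbon. That step is a 1.5-fold higher number from compound 1 to compound 2 (0.18 log units; within the scatter). Compound 3 differs from compound 1 in the core: dimethylamino in place of methoxy on a carbonyl carbon, and the step is an at least 3.3-fold higher number from compound 1 to compound 3 (0.52 log units; beyond the scatter). For compound 3 the reading sits at the limit of > 10 mg/kg in this assay, at which 1 of the 3 values shown sits, so no number is known.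

Compound 4, `CN(C)C(=O)N(C)CC#CCn1ccnc1`, is not yet measured. It stands to compound 3 exactly as compound 2 stands to compound 1, the same change in the same place: 1H-imidazol-1-yl in place of pyrrolidin-1-yl on a saturated chain carbon bound to a triple-bonded carbon. The earlier step of a 1.5-fold higher number from compound 1 to compound 2 (0.18 log units; within the scatter) stayed within the scatter. For compound 4 a step of the same kind is therefore expected, a step that the limit leaves unreadable from compound 3 to compound 4. Compound 4 is estimated at about 15 mg/kg, between 7 mg/kg and 40 mg/kg, and most probably again only a limit.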

Compound 4, dose for half-maximal effect: > 100 mg/kg
Compound 4: only a limit was reported; the forecaster's own chance of this, stated with the estimate: 70%; middle value at least 6.6-fold (0.82 log units) from the limit.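

Replacing methoxy with dimethylamino on the carbonyl carbon, already unfavourable with pyrrolidin-1-yl, gives an at least 22-fold higher number from compound 2 to compound 4 (1.34 log units; beyond the scatter) with 1H-imidazol-1-yl in this assay. Compound 4 gives only a limit, > 100 mg/kg, and compound 3 also gives only a limit, so the step between them cannot be read. The direction of the change therefore carries over to the second core, but whether its size does remains unknown: the same change on two cores in this assay, an at least 3.3-fold higher number (0.52 log units; beyond the scatter) from compound 1 to compound 3 and an at least 22-fold higher number (1.34 log units; beyond the scatter) from compound 2 to compound 4; the limit leaves it open whether they differ

The compounds shown leave open how large this change would be if both members of each pair gave a true number. They also leave open what a piperidin-1-yl group on the same chain carbon, or an ethoxy group on the carbonyl carbon, would give.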